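This account rests on a few compounds, and the source may have more. Where it says the series, first, only, none or still open, it means among the compounds named here.

The measured compounds are:
compound 1, `CC(C)(C)OC(=O)NCC1CCCN(C(=O)CN2CN(c3ccccc3)C3(CCN(C(=O)c4ccc(C5CCCCC5)cc4)CC3)C2=O)C1`: in an assay on HEK293 cells for displacement of a labelled ligand from NPC1-like intracellular cholesterol transporter 1 (Homo sapiens) (on this read-out higher numbers stand for weaker inhibition and lower numbers for stronger inhibition), compound 1 gives 3800 nM
compound 2, `CC(C)(C)OC(=O)NCC1CCCN(C(=O)CN2CN(c3ccccc3)C3(CCN(C(=O)c4ccc(C(C)(C)C)cc4)CC3)C2=O)C1`: in this assay compound 2 gives 9500 nM
compound 3, `CCOC(=O)C1CCCN(C(=O)CN2CN(c3ccccc3)C3(CCN(C(=O)c4ccc(C(C)(C)C)cc4)CC3)C2=O)C1`: in this assay compound 3 gives 8200 nM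

All three share one core, and compound 2 is the point from which the other two branch. Compound 1 differs from compound 2 by cyclohexyl in place of tert-butyl on an aromatic carbon; this step gave a 2.5-fold lower number from compound 2 to compound 1 (0.40 log units; beyond the scatter). Compound 3 differs from compound 2 by ethoxycarbonyl in place of ((tert-butoxycarbonyl)amino)methyl on a saturated ring carbon; this step gave a 1.2-fold lower number from compound 2 to compound 3 (0.06 log units; within the scatter), so the two cores are not distinguished in this read-out.

Compound 4, `CCOC(=O)C1CCCN(C(=O)CN2CN(c3ccccc3)C3(CCN(C(=O)c4ccc(C5CCCCC5)cc4)CC3)C2=O)C1`, has not been measured. It differs from compound 3 by cyclohexyl in place of tert-butyl on an aromatic carbon. This is the same change already seen once, made at the same place, only on the core of compound 3 rather than that of compound 2. Since the two cores differ in number by only a 1.2-fold lower number from compound 2 to compound 3 (0.06 log units; within the scatter), the earlier step is taken as the guide. The step from compound 3 to compound 4 is therefore expected to be about a 2.5-fold lower number from compound 3 to compound 4 (0.40 log units; beyond the scatter), because the same change once gave a 2.5-fold lower number from compound 2 to compound 1 (0.40 log units; beyond the scatter). Compound 4 is thus estimated to give about 3300 nM in this assay, most likely between 1500 nM and 7000 nM.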

Compound 4, half-maximal inhibitory concentration: 4200 nM
Compound 4: the middle estimate sits 1.3-fold (0.10 log units) below what was measured; the measured number falls inside the stated range.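

In this assay, cyclohexyl in place of tert-butyl on the core of compound 3 gave a 2.0-fold lower number from compound 3 to compound 4 (0.29 log units; within the scatter) and, set beside the earlier step, the change carries across the two cores with no difference that can be told apart: the same change on two cores in this assay, a 2.5-fold lower number (0.40 log units; beyond the scatter) from compound 2 to compound 1 and a 2.0-fold lower number (0.29 log units; within the scatter) from compound 3 to compound 4, 1.3-fold (0.11 log units) apart, within the scatter of two such steps. The other change, ethoxycarbonyl in place of ((tert-butoxycarbonyl)amino)methyl, gave a 1.1-fold higher number from compound 1 to compound 4 (0.04 log units; within the scatter) with cyclohexyl present and reads the same as it did with tert-butyl: the same change on two cores in this assay, a 1.2-fold lower number (0.06 log units; within the scatter) from compound 2 to compound 3 and a 1.1-fold higher number (0.04 log units; within the scatter) from compound 1 to compound 4, 1.3-fold (0.11 log units) apart, within the scatter of two such steps. This shows that, across these four compounds, each change reads alike whichever form the other place takes, but it rests on a single pair of cores, the new step itself lies within the scatter, and it does not show that the change would carry to any other core.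

The compounds shown leave open how a longer chain or a phenyl group would read in place of cyclohexyl on the aromatic carbon. They also leave open whether an amine or a carboxylic acid on the saturated ring carbon would read like ethoxycarbonyl.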